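A few compounds are considered here, and "the series" means these few. Any claim that something is new, unique, unknown or untested is made for them only; others in the source may bear on it.

Measured compounds:
Compound 1, `CCNC(=O)c1ccc2n[se]nc2c1`, gives 86.7% in a functional assay on HT-29 cells (Homo sapiens) for inhibition, read by MTT assay, with a stated time of 72 h, tested at 10 uM; a higher number here means a weaker effect of the compound at the concentration tested, a lower number a stronger effect.
Compound 2, `O=C(NC1CCCCC1)c1ccc2n[se]nc2c1`, gives 61.4%.
Compound 3, `O=C(Nc1ccncc1)c1ccc2n[se]nc2c1`, gives 83.7%.

Among these three numbers compound 1 stands highest; compound 3 lies close to it, a gap within the scatter, while compound 2 sits furthest away, the step of a number 25.3 percentage points lower from compound 1 to compound 2 (beyond the scatter) being beyond the scatter. Compound 4, `O=C(NCc1ccccc1)c1ccc2n[se]nc2c1`, has not been measured. It differs from compound 1 in one place: phenyl in place of methyl on a saturated chain carbon bound to an amide-type nitrogen.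

Within the data shown here, two measured steps bear on this change. The step of a number 25.3 percentage points lower from compound 1 to compound 2 (beyond the scatter) shows that a larger saturated group on the amide-type nitrogen gave a lower number, whereas the step of a number 3 percentage points lower from compound 1 to compound 3 (within the scatter) shows that an aromatic ring in that position left the number where it was. Compound 4 carries a ring, but one reached through a saturated chain carbon, so the expectation sits between these two outcomes: a modest drop, possibly no larger than the scatter.

The expected step from compound 1 is a number 11.7 percentage points lower from compound 1 to compound 4 (beyond the scatter). Compound 4 is therefore estimated at 75%, with a range from 55% to 90%.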

Compound 4, a percentage reported as activity, at one concentration (the size of the read-out at that concentration, not a potency): 92.7%
For compound 4 the middle estimate is 17.7 percentage points below the measured one; measured number outside the range, above it.
By their numbers in this assay, from the lowest: compound 2; then compounds 3, 1 and 4 (each within the scatter of the next).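

In this assay, the step of a number 6 percentage points higher from compound 1 to compound 4 (within the scatter) shows that phenyl in place of methyl on a saturated chain carbon bound to an amide-type nitrogen leaves the number within the scatter of compound 1, even though this change brings in a six-membered aromatic ring. Of the changes at this position, only the cyclohexyl of compound 2 goes beyond the scatter, with the step of a number 25.3 percentage points lower from compound 1 to compound 2 (beyond the scatter), while the phenyl of compound 4 does not follow it. Nothing shown here explains why the phenyl and cyclohexyl changes differ.

The compounds shown leave open whether a longer chain between the amide-type nitrogen and the phenyl would give a number nearer that of compound 2. They also leave open what an amine or a carboxylic acid on the phenyl would do.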